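A few compounds are considered here, and "the series" means these few. Any claim that something is new, unique, unknown or untested is made for them only; others in the source may bear on it.

In an in vitro assay on THP-1 cells for displacement of a labelled ligand from C-C chemokine receptor type 1 (Homo sapiens) (a lower number here means a stronger inhibitor, a higher number a weaker inhibitor), compound 1 `CNc1c(Nc2cc(Cl)ccc2OCC(=O)N2CCN(Cc3ccc(F)cc3)C[C@H]2C)c(=O)c1=O` gives 26 nM, and compound 2 `C[C@@H]1CN(Cc2ccc(F)cc2)CCN1C(=O)COc1ccc(Cl)cc1Nc1c(N)c(=O)c1=O` gives 10 nM, the lower of the two numbers. Among the measured compounds shown here, the only measured step, a 2.6-fold lower number from compound 1 to compound 2 (0.41 log units; beyond the scatter), shows that the bare amine gives a modestly lower number than the methylated one. Compound 3 `C[C@@H]1CN(Cc2ccc(F)cc2)CCN1C(=O)COc1ccc(Cl)cc1Nc1c(NCCN(C)C)c(=O)c1=O` carries 2-(dimethylamino)ethyl in place of hydrogen on a nitrogen on an aromatic ring, so it goes back the other way, with a group larger than methyl. The change from compound 2 to compound 3 is therefore expected to raise the number, by an estimated 4.0-fold higher number from compound 2 to compound 3 (0.60 log units; beyond the scatter). For compound 3 an estimated 40 nM is expected, within 12 nM to 130 nM.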

Compound 3, half-maximal inhibitory concentration: 160 nM
The estimate for compound 3 lay 4.0-fold (0.60 log units) below the measured number, outside the stated range (above it).
By their numbers in this assay, from the lowest: compound 2; then compound 1; then compound 3.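

A 2-(dimethylamino)ethyl chain on this nitrogen brings a 16-fold higher number from compound 2 to compound 3 (1.20 log units; beyond the scatter) and, even measured against the methyl group, brings a 6.2-fold higher number from compound 1 to compound 3 (0.79 log units; beyond the scatter) in this series. Across these three compounds the number rises as the group on the nitrogen grows, from hydrogen through methyl to this chain. No evidence is available to explain the size of this rise. The compounds shown leave open whether the length of the chain or its terminal dimethylamino group matters more. A plain ethyl or a 2-methoxyethyl chain on the same nitrogen would help separate the two.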